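Piperidine nitrogen substituent in the urea series

A few compounds are considered here, and "the series" means these few. Any claim that something is new, unique, unknown or untested is made for them only; others in the source may bear on it.

Of the compounds shown here, two of the shared core have numbers so far. Compound 1 `CN(C)Cc1cccc(-c2ccc(NC(=O)Nc3cccnc3Oc3ccccc3C(C)(C)C)c(F)c2)c1` was measured in an assay on isolated protein for binding affinity to P2Y purinoceptor 1 (Homo sapiens) (on this read-out higher numbers stand for weaker inhibition and lower numbers for stronger inhibition), and in this assay compound 1 gives 34 nM. Compound 2 `CC(C)(C)c1ccccc1Oc1ncccc1NC(=O)Nc1ccc(OCC2CCN(Cc3ccccc3)CC2)cc1F` carries a different side chain on the fluorinated ring, and in this assay compound 2 gives 11 nM. Compound 2 therefore has the lower of the two numbers, with a gap to compound 1 that lies beyond the usual scatter. Going by the values given here, no pair differing in one place has been measured, so nothing is yet known about single changes on this core.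

Compound 3 `CC(C)N1CCC(COc2ccc(NC(=O)Nc3cccnc3Oc3ccccc3C(C)(C)C)c(F)c2)CC1` differs from compound 2 in one place: isopropyl in place of benzyl on an amine nitrogen in a ring. The change keeps the basic ring amine and the ether link to the fluorinated ring intact, only the group on the ring nitrogen is exchanged. Among the compounds with values here, the step from compound 2 to compound 3 is estimated to be small, most likely a modest rise in the number, possibly none beyond the scatter, since no measured step on this core gives guidance on the ring nitrogen substituent. The expected step is a 2.3-fold higher number from compound 2 to compound 3 (0.36 log units; beyond the scatter). For compound 3 the estimated value in this assay is 25 nM, with a range from 8 nM to 80 nM.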

Compound 3, inhibition constant: 989 nM
Compound 3: middle estimate off by 40-fold (1.60 log units), on the low side; measured number outside the range, above it.
By their numbers in this assay, from the lowest: compound 2; then compound 1; then compound 3.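

In this assay, going by these compounds alone, isopropyl in place of benzyl on the amine nitrogen of the six-membered ring gives a 90-fold higher number from compound 2 to compound 3 (1.95 log units; beyond the scatter), the first single-place step on this core, so the group on this nitrogen has a large effect on the number even with the ring amine and ether link unchanged. The ether-linked ring amine is therefore not enough on its own: (1-isopropylpiperidin-4-yl)methoxy in place of 3-((dimethylamino)methyl)phenyl on an aromatic carbon gives a 29-fold higher number from compound 1 to compound 3 (1.46 log units; beyond the scatter), whereas the same link with benzyl on the nitrogen, in compound 2, has the lowest number of the three. Within the data shown here, nothing measured so far accounts for the size of either step.

Still open, as far as these compounds go, is whether the low number of compound 2 depends on the aromatic ring of benzyl or only on a larger carbon group on the nitrogen, a question that cyclohexylmethyl on the same nitrogen would address. Phenethyl there would show whether the distance from the nitrogen to the aromatic ring also matters.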